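Swapping pyridin-4-yl for 1-benzothiophen-5-yl in a clearance assay

This account rests on a few compounds, and the source may have more. Where it says the series, first, only, none or still open, it means among the compounds named here.

For the measured compounds named here, compound 2 (`Nc1ccc(S(=O)(=O)N2CCN(c3ncc(C(O)(C(F)(F)F)C(F)(F)F)cc3-c3ccncc3)CC2)cn1`) gives 15 mL.min-1.g-1 in an ADME assay (liver) for metabolic stability, with Liver microsome (Homo sapiens) as the target, using microsomes and NADPH, with a stated time of 30 min, tested at 1 uM (on this read-out lower numbers stand for slow clearance and higher numbers for fast clearance), and holds the only true number so far. Compound 1 (`Nc1ccc(S(=O)(=O)N2CCN(c3ncc(C(O)(C(F)(F)F)C(F)(F)F)cc3C#CCO)CC2)cn1`) gives < 14 mL.min-1.g-1 as a limit of the assay and not a number. Compound 3 (`Nc1ccc(S(=O)(=O)N2CCN(c3ncc(C(O)(C(F)(F)F)C(F)(F)F)cc3-c3ccc4sccc4c3)CC2)cn1`) carries 1-benzothiophen-5-yl in place of pyridin-4-yl on an aromatic carbon of the shared core (1-benzothiophen-5-yl in place of pyridin-4-yl on an aromatic carbon) and is still unmeasured. Going by the values given here, the one measured step at this place, an at least 1.0-fold higher number from compound 1 to compound 2 (0.02 log units; that floor lies within the scatter) as far as the limit allows, lies within the scatter. That step offers no size to carry over. The expectation in this assay therefore starts from compound 2 at 15 mL.min-1.g-1 and, with a larger group entering, leans cautiously toward faster clearance. Compound 3 is expected at 30 mL.min-1.g-1 with an estimated range from 15 mL.min-1.g-1 to 70 mL.min-1.g-1 on this read-out. The estimate means a 2.0-fold higher number from compound 2 to compound 3 (0.30 log units; within the scatter) as an expected step, and it remains a judgement.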

Compound 3, intrinsic clearance in microsomes: 48 mL.min-1.g-1
Compound 3: the middle estimate sits 1.6-fold (0.20 log units) below what was measured; low and high end bracket the measured number.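

For the compounds shown here, this position on the shared core does respond to the group placed on it in this assay: 1-benzothiophen-5-yl in place of pyridin-4-yl gives the first step here that clearly exceeds the scatter (a 3.2-fold higher number from compound 2 to compound 3 (0.51 log units; beyond the scatter)). Compared with 3-hydroxyprop-1-yn-1-yl, 1-benzothiophen-5-yl also gives a step beyond the scatter (an at least 3.4-fold higher number from compound 1 to compound 3 (0.53 log units; beyond the scatter)). Compound 1 stands at a limit of the assay and not a number, so that step is only a floor: (the limit of < 14 mL.min-1.g-1 in this assay, at which 1 of the 3 values shown sits).

The change swaps a six-membered ring containing nitrogen for a fused pair of rings containing sulfur, so the compounds shown cannot separate the effect of adding a ring from that of changing the hetero atom. A phenyl group or a naphthalen-2-yl group at this position would pull those two changes apart.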